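The source may hold more compounds than are shown below. What is called first, only, known or untested is meant among the compounds shown, and "the series" means these compounds.

Measured so far:
Compound 1, `CCN1CCN(CCCn2cnc3c(N4CCN(C5CCCC5)CC4)nc(NCc4ccc(N(CC)CC)cc4)nc32)CC1`: 150 nM
Compound 2, `CCN1CCN(CCCn2cnc3c(N4CCN(C(=O)C5CCCC5)CC4)nc(NCc4ccc(F)cc4)nc32)CC1`: > 30000 nM

Both were tested in an assay on HEK293 cells for antagonist activity at Toll-like receptor 9 (Homo sapiens), read by spectrophotometry; a lower number here means a stronger inhibitor, a higher number a weaker inhibitor. Compound 1 gives 150 nM, a measured number. For compound 2 the assay reports no number, only a limit, and compound 2 sits at the limit of > 30000 nM in this assay, at which 1 of the 2 values shown sits. For the measured compounds named here, compound 1 and compound 2 differ in two places at once, so their two values show only that the pair of changes together takes the result from a limit to a measured value; which of the two changes carries that shift cannot be read from these two compounds alone.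

Compound 3, `CCN1CCN(CCCn2cnc3c(N4CCN(C(=O)C5CCCC5)CC4)nc(NCc4ccc(N(CC)CC)cc4)nc32)CC1`, has not yet been measured. It differs from compound 2 in one place: diethylamino in place of fluoro on an aromatic carbon. Because compound 2 is at the limit of > 30000 nM in this assay, at which 1 of the 2 values shown sits, any measured number for compound 3 would already mean a downward step. A step beyond the scatter, in the direction of stronger inhibition, is expected: an at least 10-fold lower number from compound 2 to compound 3 (1.00 log units; beyond the scatter). Compound 3 is expected to give about 3000 nM, with a range from 400 nM to 30000 nM.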

Compound 3, half-maximal inhibitory concentration: 8800 nM
Compound 3: middle estimate off by 2.9-fold (0.47 log units), on the low side; the range from low to high includes it.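

Compound 2 has no measured number in this assay, only a limit: the limit of > 30000 nM in this assay, at which 1 of the 3 values shown sits. Diethylamino in place of fluoro on the aromatic ring gives an at least 3.4-fold lower number from compound 2 to compound 3 (0.53 log units; beyond the scatter) as a minimum, so this position does change inhibition on its own, and the true step may be larger. With diethylamino held in place, a 59-fold higher number from compound 1 to compound 3 (1.77 log units; beyond the scatter) isolates the other change, showing that cyclopentylcarbonyl in place of cyclopentyl on the ring nitrogen is enough by itself to weaken the compound markedly.

Still open, as far as these compounds go, is whether a smaller amine such as dimethylamino, or a methoxy group, would serve as well as diethylamino at this position. Also open, from the compounds shown here alone, is how much the fluoro and diethylamino groups differ when plain cyclopentyl sits on the ring nitrogen, and whether a smaller acyl group such as acetyl would carry the same cost.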